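From pyrimidin-2-yl to pyridin-2-yl at the amine nitrogen

The source may report more compounds than this note shows. Statements on the series, on what has been measured and on what is new or still open speak of the compounds shown alone.

Of the compounds shown here, three built on one shared core have been measured. In a functional assay for inhibition, with Oryctolagus cuniculus as the target (a higher number here means a weaker inhibitor, a lower number a stronger inhibitor), compound 1 `CN(C(=O)C[C@@H](N)CCCN=C(N)N)C1CN=C(NC(N)=O)NC1=O` gives 170 nM, compound 2 `CN(C(=O)C[C@@H](N)CCCCN)C1CN=C(Nc2ccccn2)NC1=O` gives 200 nM, and compound 3 `CN(C(=O)C[C@@H](N)CCCN=C(N)N)C1CN=C(Nc2ncccn2)NC1=O` gives 100 nM. Compound 3 holds the lowest number of the three, yet both gaps lie within the scatter, so no order among them can be claimed. Compound 4 `CN(C(=O)C[C@@H](N)CCCN=C(N)N)C1CN=C(Nc2ccccn2)NC1=O` differs from compound 3 by pyridin-2-yl in place of pyrimidin-2-yl on an amine nitrogen. For the measured compounds named here, the only measured step at this amine nitrogen, a 1.7-fold lower number from compound 1 to compound 3 (0.23 log units; within the scatter), stayed within the scatter. Compound 2 also carries pyridin-2-yl, but it differs from compound 3 elsewhere as well, so its value shows only that the two lie within the scatter. Compound 4 is thus expected to show no step beyond the scatter, a 1.4-fold higher number from compound 3 to compound 4 (0.15 log units; within the scatter). The estimate for compound 4 is 140 nM, with a range from 70 nM to 280 nM.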

Compound 4, half-maximal inhibitory concentration: 70 nM
Beside the measured number, compound 4's estimate is 2.0-fold (0.30 log units) above it; measured number inside the range.
By their numbers in this assay, from the lowest: compounds 4, 3, 1 and 2 (each within the scatter of the next, the first and the last beyond it).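

At the amine nitrogen, pyridin-2-yl and pyrimidin-2-yl cannot be told apart in this assay since a 1.4-fold lower number from compound 3 to compound 4 (0.15 log units; within the scatter) stays within the scatter. Pyridin-2-yl in place of carbamoyl gives a 2.4-fold lower number from compound 1 to compound 4 (0.39 log units; beyond the scatter) and so clears the scatter, which pyrimidin-2-yl did not do. On the chain, a group of 4 heavy atoms in place of a group of 2 heavy atoms gives a 2.9-fold lower number from compound 2 to compound 4 (0.46 log units; beyond the scatter) and is also a step beyond the scatter.

Nothing available explains these steps. Going by these compounds, how a phenyl group at this amine nitrogen, or a longer chain, would compare remains open.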